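Fluorine pattern on the benzoyl arm of an acylurea thiazole

The compounds below may be only part of what the source reports. "The series", "measured", "known", "first", "only" and "open" are said of these compounds alone.

Compound 1 `CN(C(=O)NC(=O)c1ccccc1F)c1nc(C(F)(F)F)c(C(=O)N/N=C/c2ccccc2C(F)(F)F)s1` is the reference for this series. In a functional assay on A549 cells (Homo sapiens) for inhibition, read by MTT assay, with a stated time of 72 h (a lower number here means a stronger inhibitor, a higher number a weaker inhibitor), compound 1 gives 6.32 ug/mL, the lowest of the two plain numbers measured; its nearest neighbour is compound 3 `CN(C(=O)NC(=O)c1ccccc1F)c1nc(C(F)(F)F)c(C(=O)N/N=C/c2cccc(C(F)(F)F)c2)s1`, which gives 19.5 ug/mL. Compound 2 `CNc1nc(C(F)(F)F)c(C(=O)N/N=C/c2ccccc2C(F)(F)F)s1` returns only a limit, > 100 ug/mL, which is the limit of the assay rather than a number (the limit of > 100 ug/mL in this assay, at which 1 of the 3 values shown sits). Two steps have been measured from compound 1. Removing the whole acyl-carbamoyl arm gives an at least 15-fold higher number from compound 1 to compound 2 (1.19 log units; beyond the scatter), the largest effect seen. Moving the trifluoromethyl on the hydrazone aryl gives a 3.1-fold higher number from compound 1 to compound 3 (0.49 log units; beyond the scatter).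

Compound 4 `CN(C(=O)NC(=O)c1ccc(F)c(F)c1)c1nc(C(F)(F)F)c(C(=O)N/N=C/c2ccccc2C(F)(F)F)s1` differs from compound 1 at the benzoyl end: 3,4-difluorophenyl in place of 2-fluorophenyl on a carbonyl carbon. For the measured compounds named here, no measured step changes this ring, so no step speaks directly to it. The step to compound 2 shows the arm must be present, while the step to compound 3 shows that rearranging substituents on an aryl ring costs a modest amount. A modest change in this assay is therefore expected, most likely a slightly higher number. The estimate for compound 4 is 10 ug/mL, between 4 ug/mL and 28 ug/mL, which is expected to mean a 1.6-fold higher number from compound 1 to compound 4 (0.20 log units; within the scatter).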

Compound 4, half-maximal inhibitory concentration: 6.96 ug/mL
Beside the measured number, compound 4's estimate is 1.4-fold (0.16 log units) above it; measured number inside the range.
By their numbers in this assay, from the lowest: compounds 1 and 4 (each within the scatter of the next); then compound 3. At a limit, above all of these: compound 2.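

In this assay, exchanging 2-fluorophenyl for 3,4-difluorophenyl on the carbonyl carbon gives a 1.1-fold higher number from compound 1 to compound 4 (0.04 log units; within the scatter) and so leaves the number unchanged within the scatter. The earlier steps shown here showed that the arm as a whole counts and that the place of the trifluoromethyl on the hydrazone aryl counts; compound 4 adds that this fluorine pattern on the benzoyl ring can differ without a change that can be read in this assay. Nothing measured here gives a reason for this result.

Only these two fluorine patterns on the ring are shown, so it remains open whether a methoxy group, an amine or a carboxylic acid on that ring would also leave the number in place. Also open, from the compounds shown here alone, is whether a pyridine or a short alkyl chain could stand in place of the phenyl on the carbonyl carbon.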